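Amide nitrogen substituent change in a thiophene-methyl amide series

The source may hold more compounds than are shown below. What is called first, only, known or untested is meant among the compounds shown, and "the series" means these compounds.

Of the compounds shown here, two have been measured. Compound 1, `Cc1ccc(OCC(=O)N(Cc2cccs2)c2cnn(C)c2)cc1`, stands as the higher of the two numbers: in an assay on HEK293 cells for agonist activity at transient receptor potential cation channel subfamily M member 8 (Homo sapiens), read by fluorescence and calcium flux, with a stated time of 15 min (on this read-out lower numbers stand for an effect already at smaller amounts and higher numbers for an effect only at larger amounts of compound), compound 1 gives 63000 nM. Compound 2, `CCN(Cc1cccs1)C(=O)COc1ccc(F)cc1`, carries a smaller group on the amide-type nitrogen and a different substituent on the aryl ring, and in this assay compound 2 gives 422 nM, which is far lower than compound 1 and well beyond the scatter. Since compound 1 and compound 2 differ in more than one place, no single change can be read from that pair.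

Compound 3, `Cc1ccc(OCC(=O)N(Cc2cccs2)C2CC2)cc1`, has not yet been measured. It differs from compound 1 as follows: cyclopropyl in place of 1-methyl-1H-pyrazol-4-yl on an amide-type nitrogen. Going by the values given here, the group that enters is small and saturated, nearer in size to the one carried by compound 2.

Given that compound 2 reaches 422 nM with a small nitrogen substituent, the step of a 21-fold lower number from compound 1 to compound 3 (1.32 log units; beyond the scatter) is expected to be downward and beyond the scatter. For compound 3 the estimate in this assay is 3000 nM, within a range of 400 nM to 25000 nM.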

Compound 3, half-maximal effective concentration: 8 nM
Beside the measured number, compound 3's estimate is 380-fold (2.57 log units) above it; measured number outside the range, below it.
By their numbers in this assay, from the lowest: compound 3; then compound 2; then compound 1.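

Working notes: in this assay the substituent on the amide-type nitrogen can now be read as a single change, which the first two compounds, differing in more than one place, did not allow. Cyclopropyl in place of 1-methyl-1H-pyrazol-4-yl gives a large step (a 7900-fold lower number from compound 1 to compound 3 (3.90 log units; beyond the scatter)), so this position alone can move the number very strongly while the rest of the core of compound 1 stays the same, and the five-membered aromatic ring is not required for an effect at low amounts of compound. No measurement at hand bears on what lies behind the size of this step.

On these data alone, it remains open whether the low number belongs to cyclopropyl in particular or is shared by other groups on this nitrogen; an isopropyl, a cyclobutyl or a phenyl group on the core of compound 3 would separate these cases. Also open is whether the step carries over when a fluorine takes the place of the methyl group on the aryl ring, as the compounds shown contain no such matched pair.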